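This account rests on a few compounds, and the source may have more. Where it says the series, first, only, none or still open, it means among the compounds named here.

In a physicochemical assay for lipophilicity, at pH 7.4 (a higher number here means a more lipophilic compound, a lower number a more polar compound), compound 1 (`CNC(=O)c1cc(C(=O)N[C@H]2[C@@H]3C[C@H](O)C[C@@H]32)cc2c1OC[C@@]2(C)c1ccccc1`) gives 3.7 while compound 2 (`CNC(=O)c1cc(C(=O)N[C@H]2[C@@H]3COC[C@@H]32)cc2c1O[C@H](CF)[C@H]2c1ccccc1`) gives 3.6 and compound 3 (`CNC(=O)c1cc(C(=O)Nc2cnn(C)c2)cc2c1OC[C@H]2c1ccccc1`) gives 3.5 as its reading. These numbers all lie within the usual scatter of one another, so compound 1 cannot be ranked against the other two. Compound 4 (`CNC(=O)c1cc(C(=O)NC2CC2)cc2c1OC[C@@]2(C)c1ccccc1`) keeps the core of compound 1 and changes one group on an amide-type nitrogen (a group of 3 heavy atoms (3 carbon; one three-membered non-aromatic ring of carbon only) in place of a group of 7 heavy atoms (6 carbon, 1 oxygen; one three-membered non-aromatic ring of carbon only, one five-membered non-aromatic ring of carbon only), on an amide-type nitrogen). Among the measured compounds shown here, no measured pair shows this change alone. The group that leaves holds more carbon but also an oxygen, and the data do not show how these balance, so only a small rise in this assay is expected, not beyond the scatter. An estimated step of a number 0.10 log units higher from compound 1 to compound 4 (within the scatter) is expected on that basis. For compound 4 the estimated value is 3.8 and the expected range runs from 3.4 to 4.2 on repeat measurement.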

Compound 4, distribution coefficient: 4
Estimate against measurement, compound 4: 0.20 log units below, within the range that was stated.
By their numbers in this assay, from the lowest: compounds 3, 2, 1 and 4 (each within the scatter of the next, the first and the last beyond it).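

Among the compounds shown here, compound 1 and compound 4 form the first pair here that differs in one place only, the group on an amide-type nitrogen. In this assay, putting cyclopropyl in place of the larger oxygen-bearing group of 7 heavy atoms gives a number 0.30 log units higher from compound 1 to compound 4 (within the scatter) on the same core, so the two compounds cannot be told apart. No measurement here explains this result.

Going by these compounds, it remains open whether an amine, a carboxylic acid or a longer carbon chain on this nitrogen would give a reading beyond the scatter.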